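The source may report more compounds than this note shows. Statements on the series, on what has been measured and on what is new or still open speak of the compounds shown alone.

For the measured compounds named here, compound 1 `Nc1ncc(-c2cc([C@H]3CCCO3)nc(N3C[C@@H]4C[C@H]3CO4)n2)nc1OC(F)F` is one of three compounds measured in an assay on Sf21 cells for inhibition of mitogen-activated protein kinase kinase kinase 13 (Homo sapiens), read by HTRF, with a stated time of 1.5 h (on this read-out lower numbers stand for stronger inhibition and higher numbers for weaker inhibition), where compound 1 gives 202 nM, the highest of the three numbers. Compound 2 `CCOC(=O)N1C[C@@H]2C[C@H]1CN2c1nc(SC)cc(-c2cnc(N)c(OC(F)F)n2)n1` gives 44 nM and compound 3 `CCOC(=O)N1C[C@@H]2C[C@H]1CN2c1nc(-c2cnc(N)c(OC(F)F)n2)cc(N2CC3CC2C3)n1` gives 13 nM. Going by the values given here, the only one-place step among the measured compounds, a 3.4-fold lower number from compound 2 to compound 3 (0.53 log units; beyond the scatter), alters a different part of the shared core and does not bear on the present comparison. Compound 4 `Nc1ncc(-c2cc([C@@H]3CCCO3)nc(N3C[C@@H]4C[C@H]3CO4)n2)nc1OC(F)F` differs from compound 1 as follows: the two compounds have the same atoms and bonds and differ only in configuration as drawn: 1 of 3 stereo elements differ; a stereocentre at a saturated ring carbon is drawn R in compound 1 and S in compound 4. Among the compounds with values here, no measured pair shows the effect of inverting this stereocentre, so the direction of any change is open. Compound 4 is therefore expected to give 200 nM, within 60 nM to 700 nM, which amounts to an expected step of a 1.0-fold lower number from compound 1 to compound 4 (0.00 log units; within the scatter), not beyond the scatter.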

Compound 4, half-maximal inhibitory concentration: 23 nM
The estimate for compound 4 lay 8.7-fold (0.94 log units) above the measured number; the measured number lies below the stated range.
By their numbers in this assay, from the lowest: compounds 3, 4 and 2 (each within the scatter of the next, the first and the last beyond it); then compound 1.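

Inverting the stereocentre at the saturated ring carbon from R to S gives an 8.8-fold lower number from compound 1 to compound 4 (0.94 log units; beyond the scatter) in this assay, so the number at this position responds to configuration, which no earlier pair could show. Nothing enters or leaves in this step, so the change rests on the stereocentre alone: the fact that compounds 1 and 4 differ only in the configuration as drawn

The compounds shown leave open whether the S form keeps this advantage when other parts of the shared core change. They also leave open what an amine or an open-chain ether would give in place of the ring carrying this stereocentre.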